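A few compounds are considered here, and "the series" means these few. Any claim that something is new, unique, unknown or untested is made for them only; others in the source may bear on it.

The measured compounds:
- compound 1, `O=C(/C=C/c1cccc(NC(=O)c2ccccc2Cl)c1)c1nc2ccccc2[nH]1`: in a functional assay on MCF7 cells (Homo sapiens) for antiproliferative activity, read by MTT assay, with a stated time of 48 h (a lower number here means a stronger inhibitor, a higher number a weaker inhibitor), compound 1 gives 4570 nM.
- compound 2, `O=C(Nc1cccc(/C=C/C(=O)c2nc3ccccc3[nH]2)c1)c1cc(Cl)cc(Cl)c1`: in this assay compound 2 reaches only a limit of the assay, > 100000 nM.

Going by the values given here, compound 1 therefore holds the only numerical value in this assay; the other result is a limit. Compound 3, `Cc1cccc(S(=O)(=O)Nc2cccc(/C=C/C(=O)c3nc4ccccc4[nH]3)c2)c1`, differs from compound 1 in one place: (3-methylphenyl)sulfonyl in place of (2-chlorophenyl)carbonyl on a nitrogen on an aromatic ring. Among the compounds with values here, the change sits on the same nitrogen that was altered between compound 1 and compound 2, yet it swaps the carbonyl for a sulfonyl and the chlorine for a methyl, and no measured step covers either of those swaps. Within the data shown here, the one step that touches this part of the molecule, an at least 21-fold higher number from compound 1 to compound 2 (1.34 log units; beyond the scatter), ended at the limit of > 100000 nM in this assay, at which 1 of the 2 values shown sits, so the only available guide points toward weaker inhibition when this group is changed, with the size of the loss uncertain. In this assay compound 3 is expected to give about 12000 nM, most likely between 2500 nM and 100000 nM, which would amount to an estimated 2.6-fold higher number from compound 1 to compound 3 (0.42 log units; beyond the scatter).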

Compound 3, half-maximal inhibitory concentration: 886 nM
The estimate for compound 3 lay 14-fold (1.13 log units) above the measured number; the whole stated range lies above it.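

The nitrogen on an aromatic ring is not a place where change only weakens the result: in this assay, (3-methylphenyl)sulfonyl in place of (2-chlorophenyl)carbonyl gives a 5.2-fold lower number from compound 1 to compound 3 (0.71 log units; beyond the scatter). Set against the (3,5-dichlorophenyl)carbonyl group, the same (3-methylphenyl)sulfonyl group gives an at least 110-fold lower number from compound 2 to compound 3 (2.05 log units; beyond the scatter), so across these three compounds the group on this nitrogen moves the result strongly in either direction. The true size of that second step cannot be fixed, since compound 2 gives a limit of the assay and not a number: the limit of > 100000 nM in this assay, at which 1 of the 3 values shown sits.

The change from compound 1 to compound 3 swaps the carbonyl for a sulfonyl and also swaps the chlorine for a methyl, so the compounds shown cannot say which swap accounts for the lower number; a (2-chlorophenyl)sulfonyl or a (3-methylphenyl)carbonyl group would separate the two. Also open, on these data alone, is whether the methyl of compound 3 matters at all, and how an amine or a carboxylic acid in its place would change the result.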